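Replacing the Dichlorophenyl Group with Isopropyl

This account rests on a few compounds, and the source may have more. Where it says the series, first, only, none or still open, it means among the compounds named here.

Measured in a functional assay on U-87MG ATCC cells (Homo sapiens) for inhibition (on this read-out higher numbers stand for weaker inhibition and lower numbers for stronger inhibition), as follows
- compound 1 `COc1cc(/C=C/C(=O)c2cccc(NC(=O)c3c(Cl)cccc3Cl)c2)ccc1O` gives 17.8 ug/mL
- compound 2 `COc1cc(/C=C/C(=O)c2cccc(NC(=O)c3ccc(Cl)cc3Cl)c2)ccc1O` gives > 50 ug/mL as a limit, not a number
- compound 3 `COc1cc(/C=C/C(=O)c2cccc(NC(=O)c3ccc(Cl)c(Cl)c3)c2)ccc1O` gives 29.5 ug/mL

Compound 1 lies within the scatter of compound 3 (a 1.7-fold higher number from compound 1 to compound 3 (0.22 log units; within the scatter)), while the gap to compound 2 is beyond it (an at least 2.8-fold higher number from compound 1 to compound 2 (0.44 log units; beyond the scatter)). Compound 4 `COc1cc(/C=C/C(=O)c2cccc(NC(=O)C(C)C)c2)ccc1O` differs from compound 1 by isopropyl in place of 2,6-dichlorophenyl on a carbonyl carbon and so has isopropyl in place of 2,6-dichlorophenyl on a carbonyl carbon. Those two steps bear on this change only loosely, since each keeps a dichlorophenyl group. They both point to higher numbers, so a modest rise is expected. The expected step is a 1.7-fold higher number from compound 1 to compound 4 (0.23 log units; within the scatter) in this estimate. For compound 4 the estimated value is 30 ug/mL with an expected range from 13 ug/mL to 65 ug/mL at its ends.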

Compound 4, half-maximal inhibitory concentration: 8.31 ug/mL
Beside the measured number, compound 4's estimate is 3.6-fold (0.56 log units) above it, and the stated range ends above it.
By their numbers in this assay, from the lowest: compound 4; then compounds 1 and 3 (each within the scatter of the next). At a limit, above all of these: compound 2.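

Compound 4 shows that a dichlorophenyl ring is not required on this carbonyl carbon: in this assay, the much smaller isopropyl group, which has no ring, gives a 2.1-fold lower number from compound 1 to compound 4 (0.33 log units; beyond the scatter) and a 3.5-fold lower number from compound 3 to compound 4 (0.55 log units; beyond the scatter). Compound 4 thus has the lowest number of the four. Compound 2 has only a limit, not a number, so the step of an at least 6.0-fold lower number from compound 2 to compound 4 (0.77 log units; beyond the scatter) is a floor: the limit of > 50 ug/mL in this assay, at which 1 of the 4 values shown sits.

The compounds shown leave open whether the lower number belongs to isopropyl itself or simply follows from losing the dichlorophenyl ring. An unsubstituted phenyl, a cyclohexyl or a longer chain such as n-butyl at this place would separate these readings.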